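The compounds below may be only part of what the source reports. "The series", "measured", "known", "first", "only" and "open" are said of these compounds alone.

Measured in a functional assay (Sus scrofa) with sulfonylurea receptors; K-ATP channels (Homo sapiens) as the target (on this read-out higher numbers stand for larger maximal responses and lower numbers for smaller maximal responses), so far:
compound 1 `O=C(Nc1c(C(O)(C(F)(F)F)C(F)(F)F)ccc2ccccc12)C1CCC1`: 97%
compound 2 `O=C(Nc1c(C(O)(C(F)(F)F)C(F)(F)F)ccc2ccccc12)c1ccc(Cl)cc1`: 99%

Within the data shown here, compound 2 sits at the upper of the two numbers, but its only neighbour, compound 1, lies within the scatter of it: the one measured step, a number 2 percentage points higher from compound 1 to compound 2 (within the scatter), 4-chlorophenyl in place of cyclobutyl on a carbonyl carbon, left the maximal response unchanged within the scatter. Both acyl groups tried on the amide-type nitrogen thus give a near-full response.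

Compound 3 `O=C(Nc1c(C(O)(C(F)(F)F)C(F)(F)F)ccc2ccccc12)c1cnco1` is the next change at the same position: 1,3-oxazol-5-yl in place of 4-chlorophenyl on a carbonyl carbon. The step 1>2 is the only one that bears on it; it shows the acyl group being swapped with no effect beyond the scatter, though between a cyclobutyl and a carbocyclic aromatic ring, not a five-membered ring with two hetero atoms. With a single precedent, the expectation for compound 3 in this assay is a step of a number 6 percentage points lower from compound 2 to compound 3 (within the scatter), that is no change beyond the scatter, with the range widened for the untested ring type. Compound 3 is therefore estimated at 93%, between 72% and 105%.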

Compound 3, largest response reached (reported as efficacy), in percent of the reference or control that the assay uses: 97%
The estimate for compound 3 lay 4 percentage points below the measured number; the measured number falls inside the stated range.
By their numbers in this assay, from the lowest: compounds 1, 3 and 2 (each within the scatter of the next).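

In this assay, the acyl position also accepts a five-membered aromatic ring with 2 hetero atoms: the change gives a number 2 percentage points lower from compound 2 to compound 3 (within the scatter), and against the cyclobutyl amide it gives no change at the digits printed from compound 1 to compound 3 (within the scatter). The 1,3-oxazol-5-yl group has 2 hydrogen-bond acceptors and 5 heavy atoms, where 4-chlorophenyl has 0 and 7, yet neither count separates these compounds on this read-out. Nothing available beyond the numbers themselves accounts for the three acyl groups reading alike.

The compounds shown do not reveal which acyl group, if any, would lower the maximal response; an acyl group carrying an amine or a carboxylic acid, or a longer alkyl chain, would test this. Also open, on these data alone, is how the response depends on the amide hydrogen and the trifluoromethyl groups, which all three compounds share.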